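Fluorophenyl for methoxyphenyl on a ring nitrogen

The source may report more compounds than this note shows. Statements on the series, on what has been measured and on what is new or still open speak of the compounds shown alone.

Compound 1 `COc1ccccc1N1CCN(CCCN(CC2CCCCC2)S(=O)(=O)c2ccc3ccccc3c2)CC1` and compound 2 `O=S(=O)(c1ccc2ccccc2c1)N(CCCN1CCN(c2ccc(F)cc2)CC1)CC1CCCCC1` share one core and differ in a single place: 4-fluorophenyl in place of 2-methoxyphenyl on an amine nitrogen in a ring. In an assay on CHO cells for displacement of a labelled ligand from 5-hydroxytryptamine receptor 7 (Homo sapiens) (on this read-out higher numbers stand for weaker inhibition and lower numbers for stronger inhibition), compound 1 gives 500 nM, and compound 2 gives 1510 nM. That one change made a 3.0-fold higher number from compound 1 to compound 2 (0.48 log units; beyond the scatter). Compound 3 `COc1ccc(S(=O)(=O)N(CCCN2CCN(c3ccccc3OC)CC2)CC2CC2)cc1` is built on another core; how the two cores differ is not broken down here. In this assay compound 3 gives 316 nM, a number close to that of compound 1 and well apart from that of compound 2. Compound 4 `COc1ccc(S(=O)(=O)N(CCCN2CCN(c3ccc(F)cc3)CC2)CC2CC2)cc1` has not yet been measured. It differs from compound 3 in the same way as compound 2 differs from compound 1: 4-fluorophenyl in place of 2-methoxyphenyl on an amine nitrogen in a ring, with the same surroundings around the place. The step from compound 3 to compound 4 is expected to resemble the earlier one, estimated at a 3.0-fold higher number from compound 3 to compound 4 (0.48 log units; beyond the scatter), because the same change produced a 3.0-fold higher number from compound 1 to compound 2 (0.48 log units; beyond the scatter) on an otherwise different core. Compound 4 is therefore expected to give about 950 nM in this assay, most likely falling between 400 nM and 2500 nM.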

Compound 4, half-maximal inhibitory concentration: 93 nM
Beside the measured number, compound 4's estimate is 10-fold (1.01 log units) above it; measured number outside the range, below it.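

On the core of compound 3, the same change gave a 3.4-fold lower number from compound 3 to compound 4 (0.53 log units; beyond the scatter) in this assay, so the direction is the reverse of that seen on the core of compound 1. The result of replacing 2-methoxyphenyl with 4-fluorophenyl therefore did not carry over from one core to the other, and the two steps disagree: the same change on two cores in this assay, a 3.0-fold higher number (0.48 log units; beyond the scatter) from compound 1 to compound 2 and a 3.4-fold lower number (0.53 log units; beyond the scatter) from compound 3 to compound 4, 10-fold (1.01 log units) apart, beyond the scatter of two such steps This shows that, in these two pairs, the outcome of the change depends on the core that carries it, but it does not show which difference between the cores matters or how the change would behave on any further core.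

The compounds shown leave open whether a core differing from compound 3 in only one of its features would keep the lower or the higher number after this change. They also leave open whether a plain phenyl or a 4-methoxyphenyl on the same ring nitrogen would help separate the part played by the methoxy group from that of the fluorine.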